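The source may hold more compounds than are shown below. What is called first, only, known or untested is meant among the compounds shown, and "the series" means these compounds.

Measured so far, in a functional assay on Caco-2 cells (Homo sapiens) for inhibition, read by MTT assay, with a stated time of 48 h; a lower number here means a stronger inhibitor, a higher number a weaker inhibitor:
Compound 1, `Fc1ccc(/C=N/Nc2nc(-c3cc(C(F)(F)F)cc(C(F)(F)F)c3)cs2)cc1F`, gives 62800 nM.
Compound 2, `COc1cc(/C=N/Nc2nc(-c3cc(C(F)(F)F)cc(C(F)(F)F)c3)cs2)cc(Br)c1OC`, reaches only > 100000 nM, which is a limit of the assay and not a number.
Compound 3, `Fc1ccc(/C=N/Nc2nc(-c3ccccc3)cs2)cc1F`, gives 20900 nM.

Compound 2 thus stands at the edge of what this assay can report. Among the measured compounds shown here, its one measured step, an at least 1.5-fold higher number from compound 1 to compound 2 (0.20 log units; that floor lies within the scatter), runs toward weaker inhibition, but its floor lies within the scatter and ends at the limit (the limit of > 100000 nM in this assay, at which 1 of the 3 values shown sits), so how far compound 2 truly lies remains open. Compound 1 and compound 3 share the 3,4-difluorophenyl group and differ only in the other aryl group; their two numbers show compound 3 with the lower value.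

Compound 4, `COc1cc(/C=N/Nc2nc(-c3cc(C(F)(F)F)cc(C(F)(F)F)c3)cs2)c(Br)c(Br)c1OC`, differs from compound 2 by a single change: bromo in place of hydrogen on an aromatic carbon. For the measured compounds named here, no measured pair here tracks a change of this kind, so the only bearing fact is that compound 2 already sits at the limit. The added bromo is not expected to bring the number back into the measurable range; the estimated step that the limit leaves unreadable from compound 2 to compound 4 is no larger than the scatter. Compound 4 is therefore expected to give about 150000 nM in this assay, within 60000 nM to 400000 nM, most likely again reported only as a limit.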

Compound 4, half-maximal inhibitory concentration: > 100000 nM
Compound 4 was reported as a limit; the forecaster's own chance of this, stated with the estimate: 75%; the middle value is on the limit's open side.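

Compound 2 and compound 4 both sit at a limit of this assay rather than at a number, so no step can be read between them: the limit of > 100000 nM in this assay, at which 2 of the 4 values shown sit.

The compounds shown leave open how strongly either compound inhibits and whether the added bromo changes that at all.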